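The compounds below may be only part of what the source reports. "The series", "measured", "known", "first", "only" and "open" are said of these compounds alone.

Compound 1 `COc1cc(-c2nnc(SCC(=O)c3ccccc3)n2N)cc(OC)c1OC` and compound 2 `COc1cc(-c2nnc(SCC(=O)c3ccc(Br)cc3)n2N)cc(OC)c1OC` share a core and differ only on the phenyl ring of the ketone. In a functional assay on HepG2 cells (Homo sapiens) for antiproliferative activity, read by MTT assay, with a stated time of 48 h (a lower number here means a stronger inhibitor, a higher number a weaker inhibitor), compound 1 gives 7800 nM, while compound 2 gives 92500 nM. Among the measured compounds shown here, compound 2 therefore stands at the weaker end of the two numbers known, and the only step that leads to it, a 12-fold higher number from compound 1 to compound 2 (1.07 log units; beyond the scatter), came from placing bromo in place of hydrogen on an aromatic carbon.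

Compound 3 `COc1cc(-c2nnc(SCC(=O)c3cccc(Br)c3)n2N)cc(OC)c1OC` keeps every atom of compound 2 but joins them differently: 3-bromophenyl in place of 4-bromophenyl on a carbonyl carbon. For the measured compounds named here, no measured pair shows what moving the bromine to another position on this ring does; the one step known, a 12-fold higher number from compound 1 to compound 2 (1.07 log units; beyond the scatter), concerns adding the bromine, not relocating it. With nothing in hand that speaks for a further move in either direction, compound 3 is expected to remain close to compound 2, with a step of a 1.3-fold lower number from compound 2 to compound 3 (0.12 log units; within the scatter) that may well fall within the scatter. Compound 3 is thus estimated at 70000 nM, with a range from 20000 nM to 250000 nM.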

Compound 3, half-maximal inhibitory concentration: 56000 nM
The estimate for compound 3 lay 1.3-fold (0.10 log units) above the measured number; low and high end bracket the measured number.
By their numbers in this assay, from the lowest: compound 1; then compounds 3 and 2 (each within the scatter of the next).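

Moving the bromine, with 3-bromophenyl in place of 4-bromophenyl on a carbonyl carbon, gives a 1.7-fold lower number from compound 2 to compound 3 (0.22 log units; within the scatter), so this assay does not tell these two placements apart. The earlier pair showed the cost of adding bromine at one placement only; a 7.2-fold higher number from compound 1 to compound 3 (0.86 log units; beyond the scatter) now stands beside a 12-fold higher number from compound 1 to compound 2 (1.07 log units; beyond the scatter), and both steps lie beyond the scatter, so the weaker reading relative to compound 1 holds for both bromo compounds shown and does not depend on the 4-bromophenyl arrangement alone. No measurement at hand gives a reason for either step.

The compounds shown leave open whether this loss belongs to bromine in particular or would follow from other groups on this phenyl ring, such as fluoro, methoxy, an amine or a carboxylic acid. They also leave open whether any replacement on this ring could bring a number lower than that of compound 1, which at 7800 nM remains the lowest of the three.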